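The source may hold more compounds than are shown below. What is called first, only, known or untested is meant among the compounds shown, and "the series" means these compounds.

Measured compounds:
compound 1, `CCCc1nc(-c2ccccc2)c(CNCCN2CCN(c3cccc(C)c3C)CC2)o1`: 1710 nM
compound 2, `CCCc1nc(-c2ccccc2)c(CNCCN2CCN(c3cccc(C(F)(F)F)c3)CC2)o1`: 1940 nM
compound 3, `CCCc1nc(-c2ccccc2)c(CNCCN2CCN(c3ccc(OC)cc3)CC2)o1`: 9200 nM

In an assay on HEK293 cells for inhibition of Voltage-dependent T-type calcium channel subunit alpha-1G (Homo sapiens), read by patch clamp (on this read-out lower numbers stand for stronger inhibition and higher numbers for weaker inhibition), compound 3 gives the highest number of the three, well beyond the scatter from compound 2 and from compound 1. Compound 4, `CCCc1nc(-c2ccccc2)c(CNCCN2CCN(c3cccc(F)c3)CC2)o1`, carries 3-fluorophenyl in place of 4-methoxyphenyl on an amine nitrogen in a ring. Among the measured compounds shown here, the steps that bear on this change are a 4.7-fold higher number from compound 2 to compound 3 (0.68 log units; beyond the scatter) and a 5.4-fold higher number from compound 1 to compound 3 (0.73 log units; beyond the scatter), both modest and both moving toward the 4-methoxyphenyl of compound 3. The step to compound 4 moves away from it, toward a substituted phenyl like those of compounds 1 and 2, so a modest drop in the number is expected, by a 3.7-fold lower number from compound 3 to compound 4 (0.57 log units; beyond the scatter). For compound 4 the expected value in this assay is 2500 nM, with a range from 1000 nM to 6000 nM.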

Compound 4, half-maximal inhibitory concentration: 3350 nM
The estimate for compound 4 lay 1.3-fold (0.13 log units) below the measured number; the range from low to high includes it.
By their numbers in this assay, from the lowest: compounds 1, 2 and 4 (each within the scatter of the next); then compound 3.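

In this assay, 3-fluorophenyl in place of 4-methoxyphenyl gives a 2.7-fold lower number from compound 3 to compound 4 (0.44 log units; beyond the scatter) on the same amine nitrogen, a step beyond the scatter. Fluoro in place of trifluoromethyl gives a 1.7-fold higher number from compound 2 to compound 4 (0.24 log units; within the scatter) and 3-fluorophenyl in place of 2,3-dimethylphenyl gives a 2.0-fold higher number from compound 1 to compound 4 (0.29 log units; within the scatter), both within the scatter, so compounds 1, 2 and 4 cannot be told apart and only compound 3 stands out. No measurement shown here explains this difference.

The compounds shown leave open whether the weaker inhibition of compound 3 follows from the methoxy group or from where it sits on the phenyl ring. A 3-methoxyphenyl or a 4-fluorophenyl on this nitrogen would separate the two.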